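The source may report more compounds than this note shows. Statements on the series, on what has been measured and on what is new or still open speak of the compounds shown alone.

Measured so far:
- Compound 1 `Clc1cccc(-c2cc3n(n2)CCCC3)n1`: 1520 nM
- Compound 2 `Clc1ccnc(COc2cc3n(n2)CCCC3)c1`: > 10000 nM
- Compound 3 `Cc1cccnc1NC(=O)c1cc2n(n1)CCCC2`: "not active" (no number reported)

All three share a core and were tested in a functional assay on HEK293 cells for negative allosteric modulation of metabotropic glutamate receptor 5 (Rattus norvegicus), read by FLIPR and calcium flux, with a stated time of 170 s; on this read-out lower numbers stand for stronger inhibition and higher numbers for weaker inhibition. Among the measured compounds shown here, compound 1 gives 1520 nM in this assay, the only plain number among the three. For compound 2 the result in this assay is > 10000 nM, which is not a number but a limit of the assay, as the limit of > 10000 nM in this assay, at which 1 of the 3 values shown sits, notes. Compound 3 stands apart from both: in this assay it is reported only as "not active" (no number reported), with no number at all, so its place among the values shown is simply that it has none and is not an active compound here.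

Compound 4 `O=C(Nc1ncccc1O)c1cc2n(n1)CCCC2` has not yet been measured. It differs from compound 3 in one place: hydroxy in place of methyl on an aromatic carbon. For the measured compounds named here, no measured step in this set connects a methyl to a hydroxy, so nothing here tells which way such a change moves the read-out in this assay. Given that compound 3 shows "not active" (no number reported), the expectation for compound 4 is no step beyond the scatter in this assay, that is, a compound that again fails to inhibit to any useful degree. The estimate for compound 4 in this assay is therefore 15000 nM, with a range from 3000 nM to 60000 nM, and a real chance that only a limit is reported.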

Compound 4, half-maximal inhibitory concentration: > 10000 nM
Compound 4: no number, only a limit; the forecaster's own chance of this, stated with the estimate: 70%; the middle value does not contradict the limit.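

In this assay compound 4 gives > 10000 nM, which is a limit and not a number. Among the compounds shown here, compound 3 reads "not active" (no number reported), so no step from compound 3 to compound 4 can be read. The compounds shown leave open whether hydroxy in place of methyl changes inhibition at all, in either direction.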